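Furan to Thiophene in a Cytotoxicity Test

A few compounds are considered here, and "the series" means these few. Any claim that something is new, unique, unknown or untested is made for them only; others in the source may bear on it.

In an ADME assay on MT4 cells (Homo sapiens) for cytotoxicity, read by MTT assay (a lower number here means that less compound is tolerated, a higher number that more compound is tolerated), three compounds sharing one core have been measured. Compound 1 (`Cc1cc(C)cc(S(=O)(=O)c2c(C(=O)NCc3ccccc3)[nH]c3ccc(Cl)cc23)c1`) gives 38000 nM, and compound 2 (`Cc1cc(C)cc(S(=O)(=O)c2c(C(=O)NNc3ccncc3)[nH]c3ccc(Cl)cc23)c1`) gives 30300 nM.

Compound 3 (`Cc1cc(C)cc(S(=O)(=O)c2c(C(=O)NCc3ccco3)[nH]c3ccc(Cl)cc23)c1`) gives > 56400 nM, which is a limit and not a number. Its place on the scale is therefore known only as the limit of > 56400 nM in this assay, at which 1 of the 3 values shown sits.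

Compound 4 (`Cc1cc(C)cc(S(=O)(=O)c2c(C(=O)NCc3cccs3)[nH]c3ccc(Cl)cc23)c1`) has thiophen-2-yl in place of furan-2-yl on a saturated chain carbon bound to an amide-type nitrogen.

Two wider swaps, which replace the whole group on the amide-type nitrogen, gave a 1.3-fold lower number from compound 1 to compound 2 (0.10 log units; within the scatter) and an at least 1.8-fold higher number from compound 2 to compound 3 (0.26 log units; that floor lies within the scatter). The closest measured change, furan-2-yl in place of phenyl at that same carbon, gave an at least 1.4-fold higher number from compound 1 to compound 3 (0.17 log units; that floor lies within the scatter), and on that basis no step beyond the scatter is expected in this assay, in either direction. The expected step is an at least 1.2-fold lower number from compound 3 to compound 4 (0.09 log units; that floor lies within the scatter). Compound 4 is estimated at about 45000 nM, with an expected range of 22000 nM to 90000 nM.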

Compound 4, half-maximal cytotoxic concentration: 54500 nM
Estimate against measurement, compound 4: 1.2-fold (0.08 log units) below; low and high end bracket the measured number.
By their numbers in this assay, from the lowest: compounds 2, 1 and 4 (each within the scatter of the next). At a limit, above all of these: compound 3.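

In this assay, compound 4 gives a true number where compound 3 gave only a limit, so this place on the saturated chain carbon now has a firm reading for a five-membered aromatic ring with one hetero atom. Thiophen-2-yl gives a 1.4-fold higher number from compound 1 to compound 4 (0.16 log units; within the scatter), and the wider swap gives a 1.8-fold higher number from compound 2 to compound 4 (0.25 log units; within the scatter), so neither step leaves the scatter. As far as these compounds go, the change from oxygen to sulfur in the ring can be read only as a floor, an at least 1.0-fold lower number from compound 3 to compound 4 (0.01 log units; that floor lies within the scatter), and its true size stays unknown because compound 3 stands at a limit: the limit of > 56400 nM in this assay, at which 1 of the 4 values shown sits.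

From the compounds shown here alone, whether a butyl chain or a carboxylic acid in place of thiophen-2-yl would move the number beyond the scatter remains open. Also open, going by these compounds, is whether thiophen-2-yl would read the same on a different core.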